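Notes on the iodo to methoxy step in this series

This account rests on a few compounds, and the source may have more. Where it says the series, first, only, none or still open, it means among the compounds named here.

Compound 3 `COc1cc(C(=O)c2sc(-c3ccc(I)cc3)cc2N)cc(OC)c1OC` stands highest of the three numbers in a functional assay on FM3A cells (Mus musculus) for antiproliferative activity (a higher number here means a weaker inhibitor, a lower number a stronger inhibitor), at 420 nM. Compound 1 `COc1cc(C(=O)c2sc(-c3ccc(F)cc3)cc2N)cc(OC)c1OC` gives 16 nM and compound 2 `COc1cc(C(=O)c2sc(-c3cccc([N+](=O)[O-])c3)cc2N)cc(OC)c1OC` gives 17 nM; the corresponding step, a 1.1-fold higher number from compound 1 to compound 2 (0.03 log units; within the scatter), lies within the scatter. The two steps that reach compound 3 are both large: a 26-fold higher number from compound 1 to compound 3 (1.42 log units; beyond the scatter) and a 25-fold higher number from compound 2 to compound 3 (1.39 log units; beyond the scatter).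

Compound 4 `COc1ccc(-c2cc(N)c(C(=O)c3cc(OC)c(OC)c(OC)c3)s2)cc1` differs from compound 3 by methoxy in place of iodo on an aromatic carbon. Going by the values given here, no measured step introduces methoxy at this position, so what bears on the change is only that the sole steps arriving at compound 3 were large rises, and compound 4 carries the iodo no longer. On that basis the step from compound 3 to compound 4 is expected to run downward and to be large, estimated as an 11-fold lower number from compound 3 to compound 4 (1.02 log units; beyond the scatter). Among the compounds with values here, compound 4 is therefore estimated in this assay at 40 nM, with a range from 10 nM to 200 nM; the range is wide because no measured compound shows methoxy at this place.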

Compound 4, half-maximal inhibitory concentration: 31 nM
Estimate against measurement, compound 4: 1.3-fold (0.11 log units) above; measured number inside the range.
By their numbers in this assay, from the lowest: compounds 1, 2 and 4 (each within the scatter of the next); then compound 3.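

In this assay the change gives a 14-fold lower number from compound 3 to compound 4 (1.13 log units; beyond the scatter) and thus shows that the high number of compound 3 does not extend to every group at this place on the ring. Methoxy puts compound 4 level with the two stronger compounds, with a 1.9-fold higher number from compound 1 to compound 4 (0.29 log units; within the scatter) and a 1.8-fold higher number from compound 2 to compound 4 (0.26 log units; within the scatter) as the readings, so that of the groups shown only iodo stands apart. No measurement here speaks to why iodo and methoxy differ so widely.

The compounds shown leave open whether bromo or chloro at this place behaves like fluoro or like iodo. Also open, going by these compounds, is whether an amine, a carboxylic acid or a longer chain such as ethoxy stays with methoxy in this assay or moves toward compound 3.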